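One Added Methyl on a Growth-Inhibiting Compound

The source may hold more compounds than are shown below. What is called first, only, known or untested is meant among the compounds shown, and "the series" means these compounds.

In a functional assay on HCT-116 cells (Homo sapiens) for inhibition, read by sulforhodamine B assay, with a stated time of 48 h, tested at 50 uM (on this read-out lower numbers stand for less inhibition of growth and higher numbers for more inhibition of growth at the one concentration tested), compound 2 (`COc1ccc([C@@H]2CC(=O)c3cc(CC=C(C)C)c(OC)cc3O2)cc1`) gives 68% inhibition. Compound 2 lies within the scatter of compound 1 (`COc1cc2c(cc1CCC(C)C)C(=O)C[C@@H](c1ccc(O)cc1)O2`) at 77% inhibition. Beyond the scatter from compound 2 lies compound 3 (`COc1ccc([C@@H]2C/C(=N/OCc3cn(-c4ccc(Cl)cc4C)nn3)c3cc(CC=C(C)C)c(OC)cc3O2)cc1`), which shows a lower 20% inhibition. Compound 4 (`CCOc1ccc([C@@H]2CC(=O)c3cc(CC=C(C)C)c(OC)cc3O2)cc1`) differs from compound 2 in one place (methyl in place of hydrogen on a saturated chain carbon bound to an oxygen on an aromatic ring): 4-methoxyphenyl becomes 4-ethoxyphenyl, with methyl in place of hydrogen on a saturated chain carbon bound to an oxygen on an aromatic ring. Going by the values given here, no measured pair shows this change, so the expectation rests only on how little is added. The step expected in this assay is none beyond the scatter (a number 3 percentage points lower from compound 2 to compound 4 (within the scatter)) and has no firm direction. Compound 4 is estimated at 65% with an expected range of 50% to 80% in this measurement.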

Compound 4, percent growth inhibition at one concentration: 65%
For compound 4 middle estimate and measured number coincide at the digits printed, within the range that was stated.
By their numbers in this assay, from the lowest: compound 3; then compounds 4, 2 and 1 (each within the scatter of the next, the first and the last beyond it).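

In this assay the change from 4-methoxyphenyl to 4-ethoxyphenyl gives a number 3 percentage points lower from compound 2 to compound 4 (within the scatter). Going by these compounds alone, this is the first pair here that differs in one place, and it shows that one added methyl on this saturated chain carbon leaves the read-out within the scatter. Nothing available explains this result. One methyl says little about a longer chain, such as butoxy, in this position. As far as these compounds go, an amine or a carboxylic acid at the end of that chain also remains open.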